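Methylsulfanyl for hydroxyethylamino on a shared nucleoside core

The source may hold more compounds than are shown below. What is called first, only, known or untested is meant among the compounds shown, and "the series" means these compounds.

Of the compounds shown here, three on a shared core have been measured in a functional assay on EL4 cells (Mus musculus) for inhibition, tested at 100 uM; on this read-out lower numbers stand for less inhibition and higher numbers for more inhibition at the one concentration tested (going by the name of the read-out). Compound 1 `OC[C@H]1OC(n2cnc3c(Nc4ccccc4)nccc32)[C@H](O)[C@@H]1O` gives 10%. Compound 2 `CN(C)c1nccc2c1ncn2C1O[C@H](CO)[C@@H](O)[C@H]1O` gives 10%. Compound 3 `OCCNc1nccc2c1ncn2C1O[C@H](CO)[C@@H](O)[C@H]1O` gives 6%. Compound 3 has the lowest of the three numbers, but its gaps to the other two are both within the scatter: a number 4 percentage points lower from compound 1 to compound 3 (within the scatter) and a number 4 percentage points lower from compound 2 to compound 3 (within the scatter). The third pair likewise shows no change at the digits printed from compound 1 to compound 2 (within the scatter).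

Compound 4 `CSc1nccc2c1ncn2C1O[C@H](CO)[C@@H](O)[C@H]1O` is not yet measured. It differs from compound 3 at one place: methylsulfanyl in place of (2-hydroxyethyl)amino on an aromatic carbon.

For the measured compounds named here, no measured step exchanges these same two groups. The two steps that alter the group on this aromatic carbon, no change at the digits printed from compound 1 to compound 2 (within the scatter) and a number 4 percentage points lower from compound 2 to compound 3 (within the scatter), each stayed within the scatter, and the step of a number 4 percentage points lower from compound 1 to compound 3 (within the scatter) did as well. Every change so far at that position has left the read-out in the same narrow band, and nothing in these data singles out methylsulfanyl. For compound 4 the expected step is therefore a number 2 percentage points higher from compound 3 to compound 4 (within the scatter), with no movement beyond the scatter anticipated in either direction. Compound 4 is estimated at 8%, with a range from -4% to 20%.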

Compound 4, a percentage reported as inhibition, at one concentration (the size of the read-out at that concentration, not a potency): < 5%
Compound 4 gave a limit, no number; the forecaster's own chance of this, stated with the estimate: 0%; middle value at least 3 percentage points away from the limit.
By their numbers in this assay, from the lowest: compounds 3, 1 and 2 (each within the scatter of the next). At a limit, below all of these: compound 4.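

In this assay compound 4 gives a limit and not a number: the limit of < 5% in this assay, at which 1 of the 4 values shown sits. Measured against the other three compounds, the steps read a number at least 1 percentage points lower from compound 3 to compound 4 (that floor lies within the scatter), a number at least 5 percentage points lower from compound 2 to compound 4 (that floor lies within the scatter) and a number at least 5 percentage points lower from compound 1 to compound 4 (that floor lies within the scatter), and all three floors lie within the scatter, so the limit does not set compound 4 apart from them. What this adds to the earlier compounds is a first group on this aromatic carbon, next to the ring nitrogen, that is attached through sulfur and not through nitrogen, and this exchange, with no hydrogen-bond donor in the entering group, still gives no step shown to lie beyond the scatter.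

Going by these compounds, how far compound 4 really lies under its limit stays open, and with it whether methylsulfanyl differs at all from anilino, dimethylamino or (2-hydroxyethyl)amino in this read-out. Also open, on these data alone, is whether any other group on this aromatic carbon, such as a carboxylic acid, a primary amine or a longer alkylsulfanyl chain, would move the number in this assay beyond the scatter in either direction.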